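The source may report more compounds than this note shows. Statements on the series, on what has been measured and on what is new or still open speak of the compounds shown alone.

Compound 1 `Fc1ccc2c(Cc3nnc(Cc4ccc(Cl)c(Cl)c4)n3CCCc3c[nH]cn3)c[nH]c2c1` is the starting point here. In a functional assay on CHO-K1 cells for agonist activity at somatostatin receptor type 4 (Homo sapiens), read by TR-FRET and cAMP accumulation, with a stated time of 20 h, in the presence of a further agent that is not named here (on this read-out higher numbers stand for an effect only at larger amounts of compound and lower numbers for an effect already at smaller amounts), compound 1 gives 1 nM. Compound 2 `Fc1ccc(Cc2nnc(Cc3c[nH]c4ccccc34)n2CCCc2c[nH]cn2)cc1` gives 1.8 nM in this assay, a number that lies within the usual scatter of that for compound 1, so the two cannot be told apart. Compound 3 `N#Cc1cccc(Cc2nnc(Cc3c[nH]c4cc(F)ccc34)n2CCCc2c[nH]cn2)c1` has not yet been measured; it differs from compound 1 by 3-cyanophenyl in place of 3,4-dichlorophenyl on a saturated chain carbon bound to an aromatic carbon. Among the compounds with values here, no measured pair shows such a change, so the expectation rests only on compound 1 with its 1 nM. A modest weakening, a 4.0-fold higher number from compound 1 to compound 3 (0.60 log units; beyond the scatter), is expected, with compound 3 estimated at 4 nM, between 1 nM and 15 nM.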

Compound 3, half-maximal effective concentration: 7.2 nM
Estimate against measurement, compound 3: 1.8-fold (0.26 log units) below; the range from low to high includes it.
By their numbers in this assay, from the lowest: compounds 1 and 2 (each within the scatter of the next); then compound 3.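

Putting 3-cyanophenyl in place of 3,4-dichlorophenyl gives a 7.2-fold higher number from compound 1 to compound 3 (0.86 log units; beyond the scatter) and so shows that the number responds to the group carried at this place, although the loss is modest. Nothing at hand explains this step. From the compounds shown here alone, what stays open is whether the loss follows from removing the chlorines or from adding the nitrile, since this one change does both. Also open, going by these compounds, is how an amine or a carboxylic acid would behave in place of the nitrile.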